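Replacing 1-methyl-1H-indol-5-yl with 4-acetylphenyl

The source may hold more compounds than are shown below. What is called first, only, known or untested is meant among the compounds shown, and "the series" means these compounds.

Measured so far in a functional assay on HCT-116 cells (Homo sapiens) for inhibition, read by CCK-8 assay, with a stated time of 48 h; a higher number here means a weaker inhibitor, a lower number a stronger inhibitor:
- compound 1 `COc1cc(-c2ccnc3cc(-c4c[nH]c5ccccc45)nn23)cc(OC)c1OC` gives 35 nM
- compound 2 `COc1cc(-c2ccnc3cc(-c4ccc(Cl)cc4)nn23)cc(OC)c1OC` gives 3340 nM
- compound 3 `COc1cc(-c2ccnc3cc(-c4ccc5c(ccn5C)c4)nn23)cc(OC)c1OC` gives 39 nM

Compound 3, at 39 nM, stands with compound 1 at the low end of the three numbers. That pair differs only within the scatter: a 1.1-fold higher number from compound 1 to compound 3 (0.05 log units; within the scatter). Compound 2 lies far off, as shown by an 86-fold lower number from compound 2 to compound 3 (1.93 log units; beyond the scatter).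

The next case is compound 4 `COc1cc(-c2ccnc3cc(-c4ccc(C(C)=O)cc4)nn23)cc(OC)c1OC`, with 4-acetylphenyl in place of 1-methyl-1H-indol-5-yl on an aromatic carbon. Among the compounds with values here, the closest measured precedent is compound 2, the only measured compound with a substituted phenyl at this place. Two large steps bear on the change: an 86-fold lower number from compound 2 to compound 3 (1.93 log units; beyond the scatter) and a 95-fold higher number from compound 1 to compound 2 (1.98 log units; beyond the scatter). Both 1H-indol-3-yl and 1-methyl-1H-indol-5-yl give low numbers, but this rests on three compounds only. Within the data shown here, no measured compound separates 4-acetylphenyl from 4-chlorophenyl, so the range stays wide.

A large step to a higher number is expected in this assay, possibly somewhat smaller than those two: a 38-fold higher number from compound 3 to compound 4 (1.59 log units; beyond the scatter). The estimated value for compound 4 is 1500 nM, with an expected range of 300 nM to 6000 nM.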

Compound 4, half-maximal inhibitory concentration: 4390 nM
Beside the measured number, compound 4's estimate is 2.9-fold (0.47 log units) below it; low and high end bracket the measured number.
By their numbers in this assay, from the lowest: compounds 1 and 3 (each within the scatter of the next); then compounds 2 and 4 (each within the scatter of the next).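

In this assay the 4-acetylphenyl group on this aromatic carbon falls far from both indolyl groups (a 110-fold higher number from compound 3 to compound 4 (2.05 log units; beyond the scatter); a 130-fold higher number from compound 1 to compound 4 (2.10 log units; beyond the scatter)), so the large gap is no longer tied to the chloro group of compound 2. Acetyl in place of chloro on the phenyl ring stays within the scatter (a 1.3-fold higher number from compound 2 to compound 4 (0.12 log units; within the scatter)), which leaves the four compounds in two clusters, the indolyl compounds 1 and 3 and the 4-substituted phenyl compounds 2 and 4, with no compound going against this split. No measured evidence here accounts for that split.

From the compounds shown here alone, it remains open whether the second ring of the indolyl groups or their ring nitrogen is what separates the clusters, a question that a naphthalen-2-yl group, with two six-membered rings of carbon only, could address. It is also open whether any phenyl group can reach the indolyl range, for example one carrying an amine or a carboxylic acid, or a substituent elsewhere on the ring than in the two 4-substituted groups shown.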